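Piperazine Amide Replaces Pyridyl Carboxamide on Shared Core

This account rests on a few compounds, and the source may have more. Where it says the series, first, only, none or still open, it means among the compounds named here.

Compound 2 `NC(=O)c1ccc(-c2cnc(C(=O)CCCCCCc3ccccc3)o2)nc1` stands lowest of the two numbers in an assay (Rattus norvegicus) for inhibition of Fatty-acid amide hydrolase 1 (Homo sapiens) (on this read-out higher numbers stand for weaker inhibition and lower numbers for stronger inhibition), where compound 2 gives 1.2 nM. In this assay, among the measured compounds shown here, compound 1 `COc1ccccc1-c1cnc(C(=O)CCCCCCc2ccccc2)o1` gives 400 nM; the step of a 330-fold lower number from compound 1 to compound 2 (2.52 log units; beyond the scatter) is the only measured step and shows how strongly the group on this carbon shapes the result. Compound 3 `CN1CCN(C(=O)c2cnc(C(=O)CCCCCCc3ccccc3)o2)CC1` differs from compound 2 in one place: (4-methylpiperazin-1-yl)carbonyl in place of 5-carbamoylpyridin-2-yl on an aromatic carbon. That measured step does not cover a non-aromatic replacement, so it is a loose guide only. Compound 3 is expected to give a higher number, a step of a 42-fold higher number from compound 2 to compound 3 (1.62 log units; beyond the scatter). Compound 3 is estimated at 50 nM, ranging from 5 nM to 500 nM.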

Compound 3, inhibition constant: 80 nM
Compound 3: middle estimate off by 1.6-fold (0.20 log units), on the low side; low and high end bracket the measured number.
By their numbers in this assay, from the lowest: compound 2; then compound 3; then compound 1.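

With equal heavy-atom counts on both sides, (4-methylpiperazin-1-yl)carbonyl in place of 5-carbamoylpyridin-2-yl still gives a 67-fold higher number from compound 2 to compound 3 (1.82 log units; beyond the scatter) in this assay, so matching that count does not preserve the number. The same group in place of 2-methoxyphenyl gives a 5.0-fold lower number from compound 1 to compound 3 (0.70 log units; beyond the scatter), which places a non-aromatic group between two aromatic ones in the order. No measurement offered here explains either step. The compounds shown leave open whether the aromatic ring or the amide hydrogen of 5-carbamoylpyridin-2-yl matters more, and how a simple carboxylic acid or a primary carboxamide on this carbon would compare.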